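This account rests on a few compounds, and the source may have more. Where it says the series, first, only, none or still open, it means among the compounds named here.

Within the data shown here, in an ADME assay on the whole organism for pharmacokinetics, with Rattus norvegicus as the target (on this read-out higher numbers stand for wider distribution into tissues and lower numbers for narrower distribution), compound 1 `CC#C[C@@H](Cc1nnn[nH]1)c1ccc(OCc2ccc3sc(F)c(-c4ccccc4C)c3c2)cc1` gives 2.2 L/kg and holds the lower of the two numbers so far, while compound 2 `CC#C[C@@H](Cc1nnn[nH]1)c1ccc(OCc2ccc3scc(-c4ccc(OCCCS(C)(=O)=O)cc4C)c3c2)cc1` gives 5.1 L/kg and lies beyond the scatter from it. Compound 3 `CC#C[C@@H](Cc1nnn[nH]1)c1ccc(OCc2ccc3sc(Cl)c(-c4ccccc4C)c3c2)cc1` differs from compound 1 in one place: chloro in place of fluoro on an aromatic carbon with chloro in place of fluoro on an aromatic carbon next to the ring sulfur. Among the measured compounds shown here, no measured pair isolates such a change, so in this assay no step beyond the scatter is expected, with any slight drift upward. The expected 1.1-fold higher number from compound 1 to compound 3 (0.04 log units; within the scatter) stays inside the scatter. Compound 3 is estimated at 2.4 L/kg with an expected range from 1.4 L/kg to 4 L/kg on repeated measurement.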

Compound 3, volume of distribution at steady state: 0.8 L/kg
Beside the measured number, compound 3's estimate is 3.0-fold (0.48 log units) above it; measured number below the stated range.
By their numbers in this assay, from the lowest: compound 3; then compound 1; then compound 2.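

On the five-membered aromatic ring with 1 sulfur, the carbon next to the ring sulfur proves responsive in this assay: chloro in place of fluoro gives a 2.8-fold lower number from compound 1 to compound 3 (0.44 log units; beyond the scatter) with no change in the counted hydrogen-bond donors, hydrogen-bond acceptors or net charge. This single-atom exchange is thus enough to move the read-out beyond the scatter. Nothing shown here accounts for the step. On these data alone, whether a methyl group or a bromo group at this carbon would extend the step remains open, and so does whether it would recur with the other aromatic groups.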